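A few compounds are considered here, and "the series" means these few. Any claim that something is new, unique, unknown or untested is made for them only; others in the source may bear on it.

In a functional assay on HepG2 cells (Homo sapiens) for inhibition, read by MTT assay, with a stated time of 48 h (on this read-out lower numbers stand for stronger inhibition and higher numbers for weaker inhibition), compound 1 `COc1ccc(-c2nc3c(c(-c4ccccc4)nn3-c3ccccc3)c(-c3ccc(N4CCCCC4)cc3)c2C#N)cc1` gives 12500 nM and compound 2 `COc1ccc(C(=O)C=CNc2cc(-c3ccccc3)nn2-c2ccccc2)cc1` gives 2030 nM, the lower of the two numbers by a gap beyond the scatter. Compound 3 `O=C(C=CNc1cc(-c2ccccc2)nn1-c1ccccc1)c1ccc(Br)cc1` has not yet been measured. Compared with compound 2, it carries bromo in place of methoxy on an aromatic carbon, turning 4-methoxyphenyl into 4-bromophenyl (bromo in place of methoxy on an aromatic carbon). Going by the values given here, no measured pair shows this swap, so the data offer no size to borrow, and the expected step of a 1.0-fold lower number from compound 2 to compound 3 (0.01 log units; within the scatter) is none beyond the scatter. For compound 3 the estimated value is 2000 nM, with an expected range from 700 nM to 6000 nM.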

Compound 3, half-maximal inhibitory concentration: 8810 nM
Estimate against measurement, compound 3: 4.4-fold (0.64 log units) below; the measured number lies above the stated range.
By their numbers in this assay, from the lowest: compound 2; then compounds 3 and 1 (each within the scatter of the next).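

In this assay, putting bromo in place of methoxy on the six-membered aromatic ring gives a 4.3-fold higher number from compound 2 to compound 3 (0.64 log units; beyond the scatter). Going by these compounds alone, this is the first direct sign that the group at this position matters, as compounds 1 and 2 differ in more than one place. No measurement is available that would explain the step. On these data alone, with only methoxy and bromo compared here, it remains open how a hydroxyl, a chloro or an amine at this position would read. As far as these compounds go, whether the same swap would have a similar effect on the core of compound 1 also remains open.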